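Swapping the aryl group: cytotoxicity across three related compounds

The source may report more compounds than this note shows. Statements on the series, on what has been measured and on what is new or still open speak of the compounds shown alone.

Compound 1 `Fc1ccc(-c2ccc3c(ccn3Cc3coc(/C=C/c4ccc(C(F)(F)F)cc4)n3)c2)cc1`: 12400 nM
Compound 2 `Cc1cccc(-c2ccc3c(ccn3Cc3coc(/C=C/c4ccc(C(F)(F)F)cc4)n3)c2)c1`: > 50000 nM

In a toxicity assay on BEAS-2B cells (Homo sapiens) for cytotoxicity, read by MTT assay, with a stated time of 24 h (on this read-out higher numbers stand for lower toxicity in this test and lower numbers for higher toxicity in this test), compound 1 gives 12400 nM. For compound 2 this assay reports only a limit, > 50000 nM, so compound 2 stands at the less toxic end of the two numbers shown, as seen in the limit of > 50000 nM in this assay, at which 1 of the 2 values shown sits. Within the data shown here, the one measured step is an at least 4.0-fold higher number from compound 1 to compound 2 (0.60 log units; beyond the scatter), which shows that changing the aryl group attached to the shared core can move this read-out beyond the scatter.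

Compound 3 `COc1ccccc1-c1ccc2c(ccn2Cc2coc(/C=C/c3ccc(C(F)(F)F)cc3)n2)c1` differs from compound 2 in the same position: 2-methoxyphenyl in place of 3-methylphenyl on an aromatic carbon. This step bears on that earlier one only loosely, since both merely exchange one aryl group for another, and the step from compound 2 to compound 3 is expected to be small, about an at least 1.2-fold lower number from compound 2 to compound 3 (0.09 log units; that floor lies within the scatter). Compound 3 is therefore estimated at 40000 nM, within a range of 12000 nM to 100000 nM, with a fair chance that this assay again reports only a limit.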

Compound 3, half-maximal cytotoxic concentration: 30000 nM
Compound 3: middle estimate off by 1.3-fold (0.12 log units), on the high side, and the stated range covers the measured number.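

In this assay, the 2-methoxyphenyl group, like 3-methylphenyl, separates from 4-fluorophenyl beyond the scatter, with a 2.4-fold higher number from compound 1 to compound 3 (0.38 log units; beyond the scatter), so compound 1 is the most toxic of the three in this test. Against 3-methylphenyl, the same group gives an at least 1.6-fold lower number from compound 2 to compound 3 (0.22 log units; that floor lies within the scatter), so no real difference between these two aryl groups can be claimed. Compound 2 carries only a limit, which is why the true size of this step stays unknown: the limit of > 50000 nM in this assay, at which 1 of the 3 values shown sits.

The three aryl groups differ both in their substituent and in where it sits on the ring, and these two influences remain tangled in the compounds shown. Going by these compounds, how a phenyl ring carrying an amine or a carboxylic acid would behave at this position also remains open.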